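Cytotoxicity in the fluorobenzyl series: from compound 3 to compound 4

This account rests on a few compounds, and the source may have more. Where it says the series, first, only, none or still open, it means among the compounds named here.

Measured so far:
compound 1, `COc1cccc2c1c(C(=O)/C=C(\O)C(=O)O)cn2Cc1ccccc1F`, 70500 nM
compound 2, `COc1cccc2c1c(C(=O)/C=C(\O)C(=O)O)cn2Cc1ccc(F)cc1`, 41100 nM
compound 3, `COc1cccc2c1c(C(=O)/C=C(\O)C(=O)O)cn2Cc1cc(F)cc(F)c1`, 29500 nM

All three share one core and differ only in the fluorophenyl group on a saturated chain carbon bound to an aromatic nitrogen. In an ADME assay on MT4 cells (Homo sapiens) for cytotoxicity, read by MTT assay (on this read-out higher numbers stand for lower toxicity in this test and lower numbers for higher toxicity in this test), compound 3 gives the lowest of the three numbers; its nearest neighbour is compound 2, and the gap between them is within the scatter, so no order between these two can be claimed. Against compound 1 the gap is larger: a 2.4-fold lower number from compound 1 to compound 3 (0.38 log units; beyond the scatter). The remaining steps, a 1.7-fold lower number from compound 1 to compound 2 (0.23 log units; within the scatter) and a 1.4-fold lower number from compound 2 to compound 3 (0.14 log units; within the scatter), are both within the scatter.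

Compound 4, `COc1cccc2c1c(C(=O)/C=C(\O)C(=O)O)cn2Cc1ccc(F)cc1F`, is the next point. Its difference from compound 3 is 2,4-difluorophenyl in place of 3,5-difluorophenyl on a saturated chain carbon bound to an aromatic nitrogen. The change bears on compound 1 and compound 2, both of which carry fluorine at one of the two positions that compound 4 now carries together, and both gave numbers within or just beyond the scatter above compound 3. The expected step is therefore small, going back upward rather than downward: a 1.5-fold higher number from compound 3 to compound 4 (0.18 log units; within the scatter). Compound 4 is estimated at 45000 nM in this assay, with a range from 22000 nM to 90000 nM.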

Compound 4, half-maximal cytotoxic concentration: 20800 nM
For compound 4 the middle estimate is 2.2-fold (0.34 log units) above the measured one; the whole stated range lies above it.
By their numbers in this assay, from the lowest: compounds 4, 3, 2 and 1 (each within the scatter of the next, the first and the last beyond it).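

In this assay, exchanging one difluorophenyl pattern for the other gives a 1.4-fold lower number from compound 3 to compound 4 (0.15 log units; within the scatter), so on a saturated chain carbon bound to an aromatic nitrogen, the 3,5-difluorophenyl and 2,4-difluorophenyl groups cannot be told apart in this test. Fluoro in place of hydrogen on an aromatic carbon gives two different readings: a 2.0-fold lower number from compound 2 to compound 4 (0.30 log units; within the scatter) stays inside the scatter, whereas a 3.4-fold lower number from compound 1 to compound 4 (0.53 log units; beyond the scatter) passes beyond it, making this the widest gap in the set and indicating modestly higher toxicity in this test for compound 4 than for compound 1. Both difluorophenyl compounds, compound 3 and compound 4, thus lie beyond the scatter from compound 1, but compound 2 goes against any clean split between one and two fluorines, as it stays within the scatter of all three other compounds; nothing available here bears on the reason for these readings.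

The compounds shown leave open how an unsubstituted benzyl group or a chlorophenyl or methoxyphenyl group at this place would read. They also leave open whether a trifluorophenyl group would extend the gap from compound 1 or leave it unchanged.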